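From Methoxy to Ethoxy on the Shared Core

This account rests on a few compounds, and the source may have more. Where it says the series, first, only, none or still open, it means among the compounds named here.

Of the compounds shown here, three sharing one core have been measured in a functional assay on MDA-MB-231 cells (Homo sapiens) for antiproliferative activity, read by sulforhodamine B assay, with a stated time of 72 h; a higher number here means a weaker inhibitor, a lower number a stronger inhibitor. In this assay compound 1 `COc1ccc(/C=C2\CCC=CC2=O)cc1` gives 1620 nM, compound 2 `COc1cccc(/C=C2\CCC=CC2=O)c1` gives 1060 nM and compound 3 `COc1ccc(/C=C2\CCC=CC2=O)cc1OC` gives 640 nM. Within the data shown here, compound 3 thus stands clear of only one of its two neighbours. Methoxy in place of hydrogen on an aromatic carbon gives a 2.5-fold lower number from compound 1 to compound 3 (0.40 log units; beyond the scatter), a modest step, and the same kind of change gives a 1.7-fold lower number from compound 2 to compound 3 (0.22 log units; within the scatter).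

Compound 4 `CCOc1ccc(/C=C2\CCC=CC2=O)cc1OC` departs from compound 3 by methyl in place of hydrogen on a saturated chain carbon bound to an oxygen on an aromatic ring, with methyl in place of hydrogen on a saturated chain carbon bound to an oxygen on an aromatic ring, which turns methoxy to ethoxy. Among the measured compounds shown here, no measured step extends such a chain, so the two methoxy steps bear on it only indirectly, and neither is large. No step beyond the scatter is therefore expected in this assay, and the expected step is a 1.1-fold higher number from compound 3 to compound 4 (0.04 log units; within the scatter). Compound 4 is estimated at 700 nM, within an expected range of 300 nM to 1500 nM.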

Compound 4, half-maximal inhibitory concentration: 600 nM
Estimate against measurement, compound 4: 1.2-fold (0.07 log units) above; the range from low to high includes it.
By their numbers in this assay, from the lowest: compounds 4, 3, 2 and 1 (each within the scatter of the next, the first and the last beyond it).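

Among these compounds, compound 4 gives the first reading of a change on the chain itself: methyl in place of hydrogen on a saturated chain carbon bound to an oxygen on an aromatic ring, which turns methoxy to ethoxy, gives a 1.1-fold lower number from compound 3 to compound 4 (0.03 log units; within the scatter) in this assay, so this position accepts the ethoxy group with no step beyond the scatter. A further single change gives a 1.8-fold lower number from compound 2 to compound 4 (0.25 log units; within the scatter), which also stays within the scatter, as the methoxy step between the same kind of neighbours did. Nothing measured here offers an explanation for this result.

The compounds shown stop at ethoxy, so a longer chain such as propoxy or butoxy remains open. So does an amine or a carboxylic acid at the end of that chain.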